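The source may hold more compounds than are shown below. What is called first, only, known or untested is meant among the compounds shown, and "the series" means these compounds.

In a functional assay on SF-268 cells (Homo sapiens) for inhibition, read by sulforhodamine B assay, with a stated time of 48 h, tested at 10 uM (on this read-out lower numbers stand for a stronger effect and higher numbers for a weaker effect at the one concentration tested), compound 1 `COc1cc(Cl)cc(-c2nn(-c3cccc(NC(=O)Nc4cccc(C(F)(F)F)c4)c3)cc2-c2ccncc2)c1` gives 27.9%, the second highest of the three numbers at hand. Within the data shown here, its closest neighbour is compound 2 `COc1cc(Cl)cc(-c2nn(-c3cccc(NC(=O)Nc4ccc(Cl)c(C(F)(F)F)c4)c3)cc2-c2ccncc2)c1`, which gives 22.9% in this assay; the only measured step, a number 5 percentage points lower from compound 1 to compound 2 (within the scatter), comes from chloro in place of hydrogen on an aromatic carbon and is within the scatter. Compound 3 `COc1cc(Cl)cc(-c2nn(-c3cccc(NC(=O)c4cc(C(F)(F)F)cc(C(F)(F)F)c4)c3)cc2-c2ccncc2)c1` stands furthest away with 89.2% in this assay, a far weaker effect than compound 1.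

Compound 4 `COc1cc(Cl)cc(-c2nn(-c3cccc(NC(=O)c4ccc(Cl)c(Cl)c4)c3)cc2-c2ccncc2)c1` has not yet been measured. The change from compound 1 is 3,4-dichlorophenyl in place of (3-(trifluoromethyl)phenyl)amino on a carbonyl carbon. Among the measured compounds shown here, no measured step covers this place on the carbonyl carbon; the step from compound 1 to compound 2 concerns another place and is too small to guide. What bears on it is the value of compound 3, whose structure resembles compound 4 more than compound 1 does. A markedly weaker effect is therefore expected for compound 4 in this assay, because compound 3 gives 89.2% while compound 1 gives 27.9%. The estimated step is a number 44.1 percentage points higher from compound 1 to compound 4 (beyond the scatter). Compound 4 is estimated at 72%, with a range from 40% to 100%.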

Compound 4, a percentage reported as activity, at one concentration (the size of the read-out at that concentration, not a potency): 82.4%
Compound 4: middle estimate off by 10.4 percentage points, on the low side; the range from low to high includes it.
By their numbers in this assay, from the lowest: compounds 2 and 1 (each within the scatter of the next); then compounds 4 and 3 (each within the scatter of the next).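

In this assay, putting 3,4-dichlorophenyl on the carbonyl carbon in place of the substituted phenylamino groups gives a number 54.5 percentage points higher from compound 1 to compound 4 (beyond the scatter) and a number 59.5 percentage points higher from compound 2 to compound 4 (beyond the scatter), both large steps in the direction of a weaker effect. Compound 3 alone could not show whether its weak effect was particular to its own aryl group, but compound 4 now stands within the scatter of compound 3, so two different aryl groups attached directly to the carbonyl carbon give similarly weak effects. No measurement at hand explains the size of these steps.

On these data alone, it remains open whether (3,4-dichlorophenyl)amino on the carbonyl carbon would restore the effect seen with compound 1 and compound 2, which would separate the role of the amino nitrogen from that of the ring. As far as these compounds go, how a benzyl group or a piperidine at this place would read is also open.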